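This account rests on a few compounds, and the source may have more. Where it says the series, first, only, none or still open, it means among the compounds named here.

Measured in a functional assay on HT-1080 cells (Homo sapiens) for cytotoxicity, read by MTT assay, with a stated time of 72 h; on this read-out higher numbers stand for weaker inhibition and lower numbers for stronger inhibition:
- Compound 1 `COc1ccc(/C=C2\CCC/C(=C\c3cccc(Br)c3)C2=O)cc1OC`: 5200 nM
- Compound 2 `COc1ccc(/C=C2\CCC/C(=C\c3cccc(O)c3)C2=O)cc1OC`: 1700 nM
- Compound 3 `COc1ccc(/C=C2\CCC/C(=C\c3ccc(Cl)c(Cl)c3)C2=O)cc1OC`: 3100 nM

Compound 3 lies within the scatter of both other compounds, with a 1.7-fold lower number from compound 1 to compound 3 (0.22 log units; within the scatter) and a 1.8-fold higher number from compound 2 to compound 3 (0.26 log units; within the scatter). Compound 4 `COc1ccc(/C=C2\CCC/C(=C\c3ccc(O)c(O)c3)C2=O)cc1OC` carries 3,4-dihydroxyphenyl in place of 3,4-dichlorophenyl on a double-bonded chain carbon bound to a double-bonded ring carbon. Within the data shown here, the closest precedent is the modest step of hydroxy in place of bromo on an aromatic carbon, a 3.1-fold lower number from compound 1 to compound 2 (0.49 log units; beyond the scatter). A similar modest fall is therefore expected in this assay. The expected change is a 2.6-fold lower number from compound 3 to compound 4 (0.41 log units; beyond the scatter). For compound 4 the estimated value is 1200 nM, with an expected range of 400 nM to 3000 nM.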

Compound 4, half-maximal inhibitory concentration: 4200 nM
Compound 4: middle estimate off by 3.5-fold (0.54 log units), on the low side; measured number above the stated range.
By their numbers in this assay, from the lowest: compounds 2, 3, 4 and 1 (each within the scatter of the next, the first and the last beyond it).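

In this assay, 3,4-dihydroxyphenyl in place of 3,4-dichlorophenyl gives a 1.4-fold higher number from compound 3 to compound 4 (0.13 log units; within the scatter), so the earlier fall on swapping bromo for hydroxy does not carry over to this change. Hydroxy in place of hydrogen on an aromatic carbon gives a 2.5-fold higher number from compound 2 to compound 4 (0.39 log units; beyond the scatter), so adding hydroxy does not lower the number here, while a 1.2-fold lower number from compound 1 to compound 4 (0.09 log units; within the scatter) leaves the bromo and dihydroxy compounds inseparable. Nothing available accounts for these results. Going by these compounds, whether an amine or a carboxylic acid on this aromatic ring would give a number outside this narrow span remains open.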